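Azetidinyl quinolone solubility notes: compound 2 to compound 3

The source may report more compounds than this note shows. Statements on the series, on what has been measured and on what is new or still open speak of the compounds shown alone.

Measured so far in a physicochemical assay for solubility, at pH 7.4; a lower number here means a less soluble compound, a higher number a more soluble compound:
- compound 1 `C[C@H]1[C@H](N)CN1c1c(F)cc2c(=O)c(C(=O)O)cn(C3CC3)c2c1Cl`: 12 ug/mL
- compound 2 `CC[C@H]1[C@@H](N)CN1c1cc2c(cc1F)c(=O)c(C(=O)O)cn2C1CC1`: 42.2 ug/mL

Compound 2 gives the highest of the two numbers recorded in this assay; its nearest neighbour is compound 1, whose value is lower by a step beyond the usual scatter. Within the data shown here, the two compounds differ in more than one place, so no single step is counted between them, and the pair is read only as two values.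

Compound 3 `CN[C@H]1CN(c2cc3c(cc2F)c(=O)c(C(=O)O)cn3C2CC2)[C@@H]1C` is not yet measured. It keeps the same atoms as compound 2 but joins them differently: a group of 7 heavy atoms (5 carbon, 2 nitrogen; one four-membered non-aromatic ring with 1 hetero atom) in place of a group of 7 heavy atoms (5 carbon, 2 nitrogen; one four-membered non-aromatic ring with 1 hetero atom), on an aromatic carbon. Among the measured compounds shown here, no measured pair shows what such a rearrangement does to this assay, so the expected step from compound 2 to compound 3 is small and most likely falls within the scatter, with no direction favoured; this estimate means a 1.1-fold lower number from compound 2 to compound 3 (0.05 log units; within the scatter).

For compound 3 the expected value in this assay is 38 ug/mL, with a range from 15 ug/mL to 95 ug/mL.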

Compound 3, solubility: 9.2 ug/mL
Compound 3: middle estimate off by 4.1-fold (0.62 log units), on the high side; the whole stated range lies above it.
By their numbers in this assay, from the lowest: compounds 3 and 1 (each within the scatter of the next); then compound 2.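

In this assay, the series now holds a pair that differs in one place, on the aromatic carbon ortho to a fluoro group, and that pair reads a 4.6-fold lower number from compound 2 to compound 3 (0.66 log units; beyond the scatter). The group that leaves and the group that enters match in every count printed for them (heavy atoms, the four-membered non-aromatic ring with 1 hetero atom, hydrogen-bond donors and acceptors, net charge, defined stereocentres), so a step beyond the scatter at this position is not foretold by those counts and depends on how the same atoms are joined. No supporting measurement at hand explains the size or direction of this step.

From the compounds shown here alone, this is a single pair on a single shared core, so it remains open whether the same rearrangement gives a step of similar size on the core of compound 1. Also open, going by these compounds, is how a dimethylamino group on the four-membered ring, or a longer chain such as propyl on it, would read in this assay against compound 2 and compound 3.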